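Oxiran-2-yl in place of 1,2-dihydroxyethyl on compound 1

This account rests on a few compounds, and the source may have more. Where it says the series, first, only, none or still open, it means among the compounds named here.

Among the measured compounds shown here, in a functional assay on JeKo-1 cells (Homo sapiens) for antiproliferative activity (on this read-out higher numbers stand for weaker inhibition and lower numbers for stronger inhibition), compound 1 (`Nc1ncnc2c1c(-c1ccc(Oc3ccccc3)cc1)cn2C[C@H]1CCCN1C[C@@H](O)CO`) gives 9540 nM, the highest of the three numbers so far and beyond the scatter from both others. Compound 2 (`CC(C)(C)c1ccc(C(=O)Nc2cccc(-c3cn([C@H]4CCN(C[C@@H]5CO5)C4)c4ncnc(N)c34)c2)cc1`) gives 2540 nM and compound 3 (`CC(C)(C)c1ccc(C(=O)Nc2ccc(-c3cn([C@H]4CCN(C[C@@H]5CO5)C4)c4ncnc(N)c34)cc2)cc1`) gives 3290 nM. Compound 4 (`Nc1ncnc2c1c(-c1ccc(Oc3ccccc3)cc1)cn2C[C@H]1CCCN1C[C@@H]1CO1`) keeps the core of compound 1 and changes one place: oxiran-2-yl in place of 1,2-dihydroxyethyl on a saturated chain carbon bound to an amine nitrogen in a ring. Oxiran-2-yl stands in place of 1,2-dihydroxyethyl on a saturated chain carbon bound to an amine nitrogen in a ring. For the measured compounds named here, no measured pair isolates this change. Going by the values given here, the only guide is that compound 2 and compound 3 both carry the (oxiran-2-yl)methyl group and both lie lower than compound 1, though they differ from it elsewhere too. A moderate fall in this assay, beyond the scatter, is therefore expected, with low confidence. The estimated step is a 3.2-fold lower number from compound 1 to compound 4 (0.50 log units; beyond the scatter). For compound 4 the expected value is 3000 nM, with an estimated range of 900 nM to 9000 nM.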

Compound 4, half-maximal inhibitory concentration: 11100 nM
Beside the measured number, compound 4's estimate is 3.7-fold (0.57 log units) below it; measured number outside the range, above it.
By their numbers in this assay, from the lowest: compounds 2 and 3 (each within the scatter of the next); then compounds 1 and 4 (each within the scatter of the next).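

With the core of compound 1 held fixed, oxiran-2-yl in place of 1,2-dihydroxyethyl on a saturated chain carbon bound to an amine nitrogen in a ring gives a 1.2-fold higher number from compound 1 to compound 4 (0.07 log units; within the scatter) in this assay. On this core, the two groups therefore cannot be told apart at this position, even though the hydrogen-bond donors of 1,2-dihydroxyethyl are gone. The (oxiran-2-yl)methyl group does not by itself bring a lower number here. Nothing among the data gives a reason for this result.

Compound 2 and compound 3 differ from compound 4 in more than one place, so the steps to them cannot be read. On these data alone, whether an amine, a carboxylic acid or a longer chain on the same chain carbon would move the number remains open.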